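Urea versus amide at the anilide position of the pyrazole series

A few compounds are considered here, and "the series" means these few. Any claim that something is new, unique, unknown or untested is made for them only; others in the source may bear on it.

Compound 1 `COc1cc(-c2nn(-c3cccc(NC(=O)Nc4cc(C(F)(F)F)cc(C(F)(F)F)c4)c3)cc2-c2ccncc2)ccc1Cl` and compound 2 `COc1cc(-c2nn(-c3cccc(NC(=O)c4cccc(C(F)(F)F)c4)c3)cc2-c2ccncc2)ccc1Cl` share a core and differ in the group joined to the carbonyl. In a functional assay on HT-29 cells (Homo sapiens) for inhibition, read by sulforhodamine B assay, with a stated time of 48 h (a lower number here means that less compound is tolerated, a higher number that more compound is tolerated), compound 1 gives 3710 nM. Going by these compounds, for compound 2 this assay reports only a limit, > 50000 nM, so compound 2 stands at the limit of > 50000 nM in this assay, at which 1 of the 2 values shown sits, and its true value is unknown. Compound 3 `COc1cc(-c2nn(-c3cccc(NC(=O)Nc4ccc(Cl)c(Cl)c4)c3)cc2-c2ccncc2)ccc1Cl` is not yet measured. It differs from compound 2 by (3,4-dichlorophenyl)amino in place of 3-(trifluoromethyl)phenyl on a carbonyl carbon, so the carbonyl of compound 3 carries a (3,4-dichlorophenyl)carbamoyl in place of the (3-(trifluoromethyl)phenyl)carbonyl of compound 2. For the measured compounds named here, no step between two measured compounds is available for this kind of change. Since compound 2 sits at a limit, any measurable value for compound 3 would read as a move to a lower number; a step of the size an at least 7.1-fold lower number from compound 2 to compound 3 (0.85 log units; beyond the scatter) is expected, towards the value of compound 1. Compound 3 is estimated at 7000 nM, with a range from 2000 nM to 30000 nM.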

Compound 3, concentration lethal to 50% of the cells: > 50000 nM
Compound 3: only a limit was reported (the forecaster's own chance of this, stated with the estimate: 20%); middle value at least 7.1-fold (0.85 log units) from the limit.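

For the compounds shown here, compound 2 and compound 3 are both reported only as a limit, so no step between them can be read: the limit of > 50000 nM in this assay, at which 2 of the 3 values shown sit. Left open is how far each lies past that limit in this assay, and so whether (3,4-dichlorophenyl)amino in place of 3-(trifluoromethyl)phenyl changes the value at all.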